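Swapping a ring on a shared core: what to expect

A few compounds are considered here, and "the series" means these few. Any claim that something is new, unique, unknown or untested is made for them only; others in the source may bear on it.

Of the compounds shown here, three sharing one core have been tested in a functional assay on PC-3 cells (Homo sapiens) for inhibition, with a stated time of 72 h; on this read-out lower numbers stand for stronger inhibition and higher numbers for weaker inhibition. Compound 1 `COc1ccc(NC(=O)Nc2nc(Sc3c[nH]c4ccccc34)cc(N3CCCCC3)n2)cc1` gives 17400 nM. Compound 2 `COc1ccc(NC(=O)Nc2nc(Sc3c[nH]c4ccccc34)cc(N3CCN(c4ccccn4)CC3)n2)cc1` gives 33400 nM. Compound 3 `O=C(Nc1ccccc1)Nc1nc(Sc2c[nH]c3ccccc23)cc(N2CCN(c3ccccn3)CC2)n1` gives 21600 nM. The three numbers sit close together: the step of a 1.9-fold lower number from compound 2 to compound 1 (0.28 log units; within the scatter) and the step of a 1.5-fold lower number from compound 2 to compound 3 (0.19 log units; within the scatter) both stay within the usual spread of repeated tests, so none of the three can be called stronger or weaker than another.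

Compound 4 `O=C(Nc1ccccc1)Nc1nc(Sc2c[nH]c3ccccc23)cc(N2CCCCC2)n1` has not yet been tested. It differs from compound 3 by piperidin-1-yl in place of 4-(pyridin-2-yl)piperazin-1-yl on an aromatic carbon. The same kind of change is already on record between two measured compounds: compound 1 differs from compound 2 by piperidin-1-yl in place of 4-(pyridin-2-yl)piperazin-1-yl on an aromatic carbon, and that step measured a 1.9-fold lower number from compound 2 to compound 1 (0.28 log units; within the scatter). The two places are not identical, though: in compound 3 the site is meta to a (phenylcarbamoyl)amino group, whereas in compound 2 it is meta to a ((4-methoxyphenyl)carbamoyl)amino group. The cores themselves differ by hydrogen in place of methoxy on an aromatic carbon.

Among the compounds with values here, since the one recorded instance of this change gave only a small step, compound 4 is expected to move from compound 3 by about a 1.8-fold lower number from compound 3 to compound 4 (0.26 log units; within the scatter), resting on the step of a 1.9-fold lower number from compound 2 to compound 1 (0.28 log units; within the scatter) and on the value of compound 3 at 21600 nM. Compound 4 is therefore estimated at 12000 nM in this assay, likely between 5000 nM and 30000 nM.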

Compound 4, half-maximal inhibitory concentration: 12100 nM
Compound 4: the middle estimate sits 1.0-fold (0.00 log units) below what was measured; measured number inside the range.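

In this assay, putting piperidin-1-yl in place of 4-(pyridin-2-yl)piperazin-1-yl on the core of compound 3 gives a 1.8-fold lower number from compound 3 to compound 4 (0.25 log units; within the scatter), and this agrees with the same swap on the core of compound 2: the same change on two cores in this assay, a 1.9-fold lower number (0.28 log units; within the scatter) from compound 2 to compound 1 and a 1.8-fold lower number (0.25 log units; within the scatter) from compound 3 to compound 4, 1.1-fold (0.03 log units) apart, within the scatter of two such steps The other swap in this set, hydrogen in place of methoxy, reads the same way, with a 1.4-fold lower number from compound 1 to compound 4 (0.16 log units; within the scatter) standing close to the earlier step: the same change on two cores in this assay, a 1.5-fold lower number (0.19 log units; within the scatter) from compound 2 to compound 3 and a 1.4-fold lower number (0.16 log units; within the scatter) from compound 1 to compound 4, 1.1-fold (0.03 log units) apart, within the scatter of two such steps So, on these four compounds, each swap gave a step of about the same size on both cores, but every step lies within the usual spread of repeated tests, which means this does not show that either swap really alters inhibition, and the agreement between such small steps is weak evidence that a swap's effect carries from one core to another.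

From the compounds shown here alone, what a group such as morpholin-4-yl or an open-chain amine would do in place of piperidin-1-yl remains open, as does the effect of a chlorine or a carboxylic acid in place of methoxy. Going by these compounds, the (1H-indol-3-yl)sulfanyl group is the same in all four compounds, so its contribution also remains unknown, and a replacement such as a phenylsulfanyl group could test whether it matters.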